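A few compounds are considered here, and "the series" means these few. Any claim that something is new, unique, unknown or untested is made for them only; others in the source may bear on it.

Values in a functional assay on MCF7 cells (Homo sapiens) for cytotoxicity, read by MTT assay, with a stated time of 72 h (on this read-out lower numbers stand for stronger inhibition and higher numbers for weaker inhibition), so far
- Compound 1 `COc1ncc(-c2ccc3nc(NC(=O)NC4CC4)nn3c2)cc1NS(=O)(=O)c1ccc(F)cc1` gives 300 nM
- Compound 2 `COc1ncc(-c2ccc3nc(NC(=O)NCC(=O)N4CCCC4)nn3c2)cc1NS(=O)(=O)c1ccc(F)cc1` gives 2130 nM
- Compound 3 `CCN(CC)CCNC(=O)Nc1nc2ccc(-c3cnc(OC)c(NS(=O)(=O)c4ccc(F)cc4F)c3)cn2n1` gives 740 nM

Compound 2 at 2130 nM holds the highest number of the three, and compound 3 and compound 1 both stand lower. The step of interest leads from compound 2 to compound 4 `CNC(=O)Nc1nc2ccc(-c3cnc(OC)c(NS(=O)(=O)c4ccc(F)cc4)c3)cn2n1` and is counted as hydrogen in place of (pyrrolidin-1-yl)carbonyl on a saturated chain carbon bound to an amide-type nitrogen in the structures. In words, this is hydrogen in place of (pyrrolidin-1-yl)carbonyl on a saturated chain carbon bound to an amide-type nitrogen, which also reads as ((pyrrolidin-1-yl)carbonyl)methyl to methyl.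

Going by the values given here, only one measured step bears on this directly. The step of a 7.1-fold higher number from compound 1 to compound 2 (0.85 log units; beyond the scatter) is modest and beyond the scatter, and it brought in the same ((pyrrolidin-1-yl)carbonyl)methyl group in place of cyclopropyl. Compound 3 differs from compound 2 in more than one place and offers only a general reference. Among the compounds with values here, no measured compound yet carries the methyl group, so the size of the reversal remains uncertain.

Most of that modest step is expected to reverse in this assay and to give a lower number. The expected change is a 4.7-fold lower number from compound 2 to compound 4 (0.68 log units; beyond the scatter) in this estimate. In this assay compound 4 is estimated at 450 nM with a range of 170 nM to 1200 nM expected.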

Compound 4, half-maximal inhibitory concentration: 250 nM
Compound 4: the middle estimate sits 1.8-fold (0.26 log units) above what was measured, within the range that was stated.
By their numbers in this assay, from the lowest: compounds 4 and 1 (each within the scatter of the next); then compound 3; then compound 2.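

Working notes on the urea side chain, read in this assay: taking the (pyrrolidin-1-yl)carbonyl off the saturated chain carbon bound to an amide-type nitrogen gives the step (an 8.5-fold lower number from compound 2 to compound 4 (0.93 log units; beyond the scatter)), which shows that the higher number of compound 2 goes with this group and that a small methyl on the amide-type nitrogen carries no such cost. Methyl and cyclopropyl at this place cannot be told apart in this read-out (a 1.2-fold lower number from compound 1 to compound 4 (0.08 log units; within the scatter)), so among compound 1, compound 2 and compound 4 only the ((pyrrolidin-1-yl)carbonyl)methyl group separates from the others. No measurement on hand gives a cause for either step.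

Going by these compounds, it remains open whether the higher number of compound 2 follows from the pyrrolidine ring, the carbonyl or simply the length of the substituent. A plain alkyl chain longer than methyl, such as n-butyl, or a carboxylic acid in place of the pyrrolidine amide on the same chain carbon would begin to separate these parts.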